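Cytotoxicity Limits Across an Ester-to-Amide Change

A few compounds are considered here, and "the series" means these few. Any claim that something is new, unique, unknown or untested is made for them only; others in the source may bear on it.

Compound 1, `Cc1cccc(C(=O)OC2CCC(CN3CCN(c4cc(=O)c5cc(C(F)(F)F)cc([N+](=O)[O-])c5s4)CC3)CC2)c1`: in an ADME assay on Vero cells (Chlorocebus sabaeus) for cytotoxicity, read by MTT assay, with a stated time of 48 h (a lower number here means a stronger inhibitor, a higher number a weaker inhibitor), compound 1 gives > 64 ug/mL, which is a limit of the assay rather than a number.
Compound 2, `O=C(OC1CCC(CN2CCN(c3cc(=O)c4cc(C(F)(F)F)cc([N+](=O)[O-])c4s3)CC2)CC1)C1CCC1`: compound 2 gives > 64 ug/mL, again a limit.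
Compound 3, `O=C(OC1CCC(CN2CCN(c3cc(=O)c4cc(C(F)(F)F)cc([N+](=O)[O-])c4s3)CC2)CC1)c1cccc(F)c1`: compound 3 gives > 64 ug/mL, again a limit.

Compound 1 therefore stands at the top of what this assay reports, and so do the other two: the limit of > 64 ug/mL in this assay, at which 3 of the 3 values shown sit. The measured steps are a step that the two limits leave unreadable from compound 1 to compound 2, a step that the two limits leave unreadable from compound 1 to compound 3 and a step that the two limits leave unreadable from compound 2 to compound 3; none of them has a readable size, so they set no scale for any change.

Compound 4, `CC(=O)NC1CCC(CN2CCN(c3cc(=O)c4cc(C(F)(F)F)cc([N+](=O)[O-])c4s3)CC2)CC1`, differs from compound 1 as follows: acetamido in place of ((3-methylphenyl)carbonyl)oxy on a saturated ring carbon. Within the data shown here, no measured step touches this position in the same way; the measured steps only swapped the group on the carbonyl carbon. Nothing in the three measured compounds points to a step beyond the scatter, and another limit is the most likely outcome. Compound 4 is thus expected to give 64 ug/mL, with a range from 32 ug/mL to 128 ug/mL. The expected step is a number no higher from compound 1 to compound 4 (the limit leaves the size open).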

Compound 4, half-maximal inhibitory concentration: > 64 ug/mL
Compound 4 ended at the assay's limit; the forecaster's own chance of this, stated with the estimate: 80%; the middle value sits exactly at the limit.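

The steps from compound 1, compound 2 and compound 3 to compound 4 cannot be read, because each joins two limits rather than two numbers: the limit of > 64 ug/mL in this assay, at which 4 of the 4 values shown sit.

The compounds shown leave open how far apart the four truly lie in this assay, and whether any of these changes alters the value at all.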